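Swapping the Aryl Ketone Substituent on a Thiophene Scaffold

The source may hold more compounds than are shown below. What is called first, only, known or untested is meant among the compounds shown, and "the series" means these compounds.

Compound 3 `CC(C)(C)Cc1c(-c2ccccc2)sc(N)c1C(=O)c1ccc(Cl)cc1Cl` is tested in an assay on CHO cells for displacement of a labelled ligand from adenosine receptor A3 (Homo sapiens), read by scintillation counting, tested at 10 uM (on this read-out lower numbers stand for less inhibition and higher numbers for more inhibition at the one concentration tested (going by the name of the read-out)), where it gives 1%. Compound 1 `Cc1ccc(C(=O)c2c(N)sc(Br)c2CC(C)(C)C)cc1` gives 1% in this assay, the same reading at the digits shown, and compound 2 `CC(C)(C)Cc1c(-c2ccccc2)sc(N)c1C(=O)c1ccc(Cl)c(Cl)c1` gives 6%; the one measured step, a number 5 percentage points lower from compound 2 to compound 3 (within the scatter), stays within the scatter. Compound 4 `Cc1ccc(C(=O)c2c(N)sc(-c3ccccc3)c2CC(C)(C)C)cc1` carries 4-methylphenyl in place of 2,4-dichlorophenyl on a carbonyl carbon. For the measured compounds named here, the only measured step concerns an exchange of one dichlorophenyl for another on that same carbonyl carbon, and it moved the reading by little, so a similar exchange of the aryl group is expected to leave the number near the others: the step of a number 2 percentage points higher from compound 3 to compound 4 (within the scatter) is expected to stay within the scatter. Compound 4 is therefore estimated to give 3%, in the range -5% to 12%.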

Compound 4, a percentage reported as inhibition, at one concentration (the size of the read-out at that concentration, not a potency): 1%
Beside the measured number, compound 4's estimate is 2 percentage points above it; the measured number falls inside the stated range.
By their numbers in this assay, from the lowest: compounds 1, 3, 4 and 2 (each within the scatter of the next).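

In this assay, 4-methylphenyl on the carbonyl carbon gives no change at the digits printed from compound 3 to compound 4 (within the scatter) and a number 5 percentage points lower from compound 2 to compound 4 (within the scatter) so the reading now holds within the scatter for an aryl ring without chlorine, not only between two dichlorophenyl groups. At a second place, an aromatic carbon, phenyl in place of bromo gives no change at the digits printed from compound 1 to compound 4 (within the scatter) and this is the first step shown there. Nothing available accounts for these readings.

Still open, from the compounds shown here alone, is whether an amine or a carboxylic acid on that aromatic carbon would shift the reading. A non-aromatic group, such as a longer chain, on the carbonyl carbon is equally untested by these compounds.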